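Swapping 6-hydroxyhexyl for oxolan-2-yl: what to expect

The source may report more compounds than this note shows. Statements on the series, on what has been measured and on what is new or still open speak of the compounds shown alone.

- Compound 1 `O=S(=O)(/C=C/c1ccc(O)c(O)c1)CC1CCCCC1`: 7500 nM
- Compound 2 `O=S(=O)(/C=C/c1ccc(O)c(O)c1)CC1CC1`: 10500 nM
- Compound 3 `O=S(=O)(/C=C/c1ccc(O)c(O)c1)CCCCCCCO`: 5900 nM

In a functional assay, read by fluorescence and spectrophotometry, with a stated time of 1 h (a lower number here means that less compound is needed, a higher number that more compound is needed for the effect), compound 3 stands within the usual scatter of both other compounds: a 1.3-fold lower number from compound 1 to compound 3 (0.10 log units; within the scatter) and a 1.8-fold lower number from compound 2 to compound 3 (0.25 log units; within the scatter). Compound 4 `O=S(=O)(/C=C/c1ccc(O)c(O)c1)CC1CCCO1` changes one group: oxolan-2-yl in place of 6-hydroxyhexyl on a saturated chain carbon bound to a sulfonyl sulfur. Here, oxolan-2-yl replaces 6-hydroxyhexyl on a saturated chain carbon bound to a sulfonyl sulfur. The third measured step at this place is a 1.4-fold higher number from compound 1 to compound 2 (0.15 log units; within the scatter). All three steps stayed within the scatter, so a step beyond the scatter is not expected here. The expected step is a 1.4-fold higher number from compound 3 to compound 4 (0.16 log units; within the scatter). Compound 4 is estimated at 8500 nM, with an expected range from 4500 nM to 16000 nM.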

Compound 4, half-maximal effective concentration: 10500 nM
The estimate for compound 4 lay 1.2-fold (0.09 log units) below the measured number; the range from low to high includes it.
By their numbers in this assay, from the lowest: compounds 3, 1, 2 and 4 (each within the scatter of the next).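

In this assay, oxolan-2-yl stays within the scatter of 6-hydroxyhexyl (a 1.8-fold higher number from compound 3 to compound 4 (0.25 log units; within the scatter)), cyclopropyl (no change at the digits printed from compound 2 to compound 4 (within the scatter)) and cyclohexyl (a 1.4-fold higher number from compound 1 to compound 4 (0.15 log units; within the scatter)). So at this place, a five-membered ring holding an oxygen, with no hydrogen-bond donor, gives a number that cannot be told apart from those of the two carbon rings or the open chain with its hydroxyl. No further data are available to explain these numbers.

The compounds shown include no amine or carboxylic acid at this place, so it remains open whether either would give a step beyond the scatter.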